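Replacing an Ester Methoxy with Amino on a Nucleoside Sultone

This account rests on a few compounds, and the source may have more. Where it says the series, first, only, none or still open, it means among the compounds named here.

Compound 1 `CCOC(=O)NC(=O)NC1=CS(=O)(=O)O[C@@]12[C@@H](CO[Si](C)(C)C(C)(C)C)O[C@@H](n1cc(C)c(=O)n(C)c1=O)[C@@H]2O[Si](C)(C)C(C)(C)C`: 3000 nM
Compound 2 `Cc1cn([C@@H]2O[C@@H]3COC4(O)CS(=O)(=O)O[C@@]34[C@H]2O[Si](C)(C)C(C)(C)C)c(=O)[nH]c1=O`: 100000 nM
Compound 3 `COC(=O)CNC1=CS(=O)(=O)O[C@@]12[C@@H](CO[Si](C)(C)C(C)(C)C)O[C@@H](n1cc(C)c(=O)n(C)c1=O)[C@@H]2O[Si](C)(C)C(C)(C)C`: 96000 nM

In a functional assay on CCRF-CEM cells (Homo sapiens) (on this read-out lower numbers stand for higher toxicity in this test and higher numbers for lower toxicity in this test), compound 3 gives 96000 nM, the second highest of the three numbers; compound 2 sits within the scatter of it, while compound 1 lies far lower. Compound 4 `Cc1cn([C@@H]2O[C@H](CO[Si](C)(C)C(C)(C)C)[C@@]3(OS(=O)(=O)C=C3NCC(N)=O)[C@H]2O[Si](C)(C)C(C)(C)C)c(=O)n(C)c1=O` differs from compound 3 by amino in place of methoxy on a carbonyl carbon. Within the data shown here, the only measured step, a 32-fold higher number from compound 1 to compound 3 (1.51 log units; beyond the scatter), exchanged the whole group on the amine nitrogen and left the carbonyl substituent changed here untouched, so no direct precedent exists. With the shared core and the amine kept, the step is expected to stay within the scatter: a 1.2-fold lower number from compound 3 to compound 4 (0.08 log units; within the scatter). Compound 4 is therefore estimated at 80000 nM, in a range from 20000 nM to 200000 nM.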

Compound 4, half-maximal cytotoxic concentration: 14600 nM
Estimate against measurement, compound 4: 5.5-fold (0.74 log units) above; measured number below the stated range.
By their numbers in this assay, from the lowest: compound 1; then compound 4; then compounds 3 and 2 (each within the scatter of the next).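

At this position the carbonyl substituent matters in this assay: with the rest of the molecule unchanged, amino in place of methoxy gives a 6.6-fold lower number from compound 3 to compound 4 (0.82 log units; beyond the scatter) and so moves the number beyond the scatter. The gain over compound 3 is only partial, since carbamoylmethyl on the amine nitrogen still leaves a 4.9-fold higher number from compound 1 to compound 4 (0.69 log units; beyond the scatter) against (ethoxycarbonyl)carbamoyl. Nothing measured here accounts for the shift. Open, as far as these compounds go, is how a carboxylic acid or a methylamino group on the same carbonyl carbon would compare with amino, and whether a longer chain on the amine nitrogen would shift the number further.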